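Methoxyphenyl for hydroxyphenyl on the shared core

The source may hold more compounds than are shown below. What is called first, only, known or untested is meant among the compounds shown, and "the series" means these compounds.

Compound 3 `COc1ccc(-c2cc3cc(C)ccc3c(-c3cccc(O)c3)n2)cc1OC` gives 13500 nM in an ADME assay on MCF-10A cells (Homo sapiens) for cytotoxicity, read by CCK-8 assay and cell counting, with a stated time of 72 h (on this read-out higher numbers stand for weaker inhibition and lower numbers for stronger inhibition), and compound 1 `COc1ccc(-c2cc3ccccc3c(-c3cccc(N)c3)n2)cc1` gives 18800 nM in this assay, within the scatter of compound 3. Compound 2 `COc1ccc(-c2cc3ccccc3c(-c3ccc(OC)cc3)n2)cc1` reaches only a limit, > 50000 nM in this assay. Compound 4 `COc1ccc(-c2nc(-c3ccc(OC)c(OC)c3)cc3cc(C)ccc23)cc1` differs from compound 3 by 4-methoxyphenyl in place of 3-hydroxyphenyl on an aromatic carbon. For the measured compounds named here, one measured step bears on this: an at least 2.6-fold higher number from compound 1 to compound 2 (0.42 log units; beyond the scatter), where a methoxy-bearing ring likewise replaced a donor-bearing ring and the number stopped at the limit (the limit of > 50000 nM in this assay, at which 1 of the 3 values shown sits). A rise in this assay of comparable size is therefore expected for compound 4, with a fair chance that only a limit results. The estimate for compound 4 in this assay is 35000 nM, ranging from 15000 nM to 80000 nM. The step this implies is expected to be a 2.6-fold higher number from compound 3 to compound 4 (0.41 log units; beyond the scatter).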

Compound 4, half-maximal inhibitory concentration: > 50000 nM
Compound 4 was reported as a limit; the forecaster's own chance of this, stated with the estimate: 40%; middle value at least 1.4-fold (0.15 log units) from the limit.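

At this place, next to the ring nitrogen, 4-methoxyphenyl in place of 3-hydroxyphenyl gives an at least 3.7-fold higher number from compound 3 to compound 4 (0.56 log units; beyond the scatter), so the rise seen with 3-aminophenyl also appears with a different leaving ring and on the core of compound 3. The value of compound 4 is a limit, not a number. Across the compounds shown, the 3-aminophenyl and 3-hydroxyphenyl compounds give numbers and both 4-methoxyphenyl compounds give limits, with no compound against this.

Going by these compounds, whether a ring bearing a carboxylic acid or a longer ether chain would also reach the limit stays open. The full size of the step also stays open because the number stops at the limit: the limit of > 50000 nM in this assay, at which 2 of the 4 values shown sit.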